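This account rests on a few compounds, and the source may have more. Where it says the series, first, only, none or still open, it means among the compounds named here.

Compound 1 `N#C/C(=C\c1ccc[nH]1)C(=O)NCc1ccc(Cl)c(Cl)c1`: 6000 nM
Compound 2 `N#C/C(=C\c1ccccc1)C(=O)NCc1ccc(Cl)c(Cl)c1`: 29000 nM

Going by the values given here, in a functional assay on MCF7 cells (Homo sapiens) for inhibition, read by MTT assay, with a stated time of 72 h (on this read-out lower numbers stand for stronger inhibition of growth and higher numbers for weaker inhibition of growth), compound 2 gives 29000 nM, the higher of the two numbers measured so far; compound 1 gives 6000 nM, and the step of a 4.8-fold higher number from compound 1 to compound 2 (0.68 log units; beyond the scatter) lies beyond the scatter. Compound 3 `N#C/C(=C\c1ccc(Cl)cc1)C(=O)NCc1ccc(Cl)c(Cl)c1` differs from compound 2 by chloro in place of hydrogen on an aromatic carbon. Among the compounds with values here, the only measured step concerns a different change, the swap of one ring for another on the double-bonded chain carbon; no measured pair shows what a chloro added to that phenyl ring does. That step therefore bears on compound 3 only by showing how far a single change at this end of the molecule can move the number. Without a direct precedent, the step from compound 2 to compound 3 is estimated as a 1.9-fold lower number from compound 2 to compound 3 (0.29 log units; within the scatter), of uncertain direction and possibly within the scatter. Compound 3 is expected to give about 15000 nM, within a range from 5000 nM to 45000 nM.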

Compound 3, concentration for 50% growth inhibition: 21000 nM
The estimate for compound 3 lay 1.4-fold (0.15 log units) below the measured number; low and high end bracket the measured number.
By their numbers in this assay, from the lowest: compound 1; then compounds 3 and 2 (each within the scatter of the next).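

In this assay, a chloro on the phenyl ring, para to a large group, gives a 1.4-fold lower number from compound 2 to compound 3 (0.14 log units; within the scatter), so at this place the added chlorine does not separate compound 3 from compound 2. The comparison with the 1H-pyrrol-2-yl ring also holds up with the new group in place, at a 3.5-fold higher number from compound 1 to compound 3 (0.54 log units; beyond the scatter), so that ring gives the lower number against 4-chlorophenyl as well as against phenyl. Nothing measured here offers a reason for either step.

On these data alone, whether a different group at this place, such as an amine or a carboxylic acid, would move the number beyond the scatter remains open, as does the effect of chloro elsewhere on the ring. As far as these compounds go, it is also open whether the lower number of compound 1 would survive a methyl on the ring nitrogen of its 1H-pyrrol-2-yl group.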